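Phenyl to Methyl on the Shared Core

This account rests on a few compounds, and the source may have more. Where it says the series, first, only, none or still open, it means among the compounds named here.

Within the data shown here, compound 2 `C/C(=N\Nc1nc(-c2ccccc2)cs1)c1cc2ccccc2o1` gives 8490 nM in a functional assay on MCF7 cells (Homo sapiens) for antiproliferative activity (on this read-out lower numbers stand for stronger inhibition and higher numbers for weaker inhibition), the lowest of the two numbers, with compound 1 `COc1ccc(-c2csc(N/N=C(\C)c3cc4ccccc4o3)n2)cc1` at 18900 nM as its only neighbour. Compound 3 `C/C(=N\Nc1nc(C)cs1)c1cc2ccccc2o1` differs from compound 2 by methyl in place of phenyl on an aromatic carbon. Among the measured compounds shown here, the single measured step, a 2.2-fold lower number from compound 1 to compound 2 (0.35 log units; beyond the scatter), concerns a different position and trims only a methoxy, so it cannot be carried over directly. Removing a whole ring, without measured precedent, is estimated to weaken inhibition: compound 3 is expected at 20000 nM, within 6000 nM to 60000 nM, a step of a 2.4-fold higher number from compound 2 to compound 3 (0.37 log units; beyond the scatter).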

Compound 3, half-maximal inhibitory concentration: 4890 nM
Compound 3: middle estimate off by 4.1-fold (0.61 log units), on the high side; the whole stated range lies above it.
By their numbers in this assay, from the lowest: compounds 3 and 2 (each within the scatter of the next); then compound 1.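

In this assay, putting methyl in place of phenyl gives a 1.7-fold lower number from compound 2 to compound 3 (0.24 log units; within the scatter) and shows that, for these two compounds, the six-membered aromatic ring on this carbon can go without a change beyond the scatter. Methyl in place of 4-methoxyphenyl gives a 3.9-fold lower number from compound 1 to compound 3 (0.59 log units; beyond the scatter) and is a step beyond the scatter, so the smaller group compares favourably with the larger substituted ring. Nothing available explains this result. From the compounds shown here alone, how an amine, a carboxylic acid or a longer chain on this carbon would fare stays open. Going by these compounds, whether the hydrogen-only parent of this position would match methyl also remains unknown.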